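A few compounds are considered here, and "the series" means these few. Any claim that something is new, unique, unknown or untested is made for them only; others in the source may bear on it.

Measured compounds:
Compound 1 `C/N=C(\S)NCCCCCn1nc(-c2ccccc2)ccc1=O` — 68.9%
Compound 2 `C/N=C(/NC#N)NCCCCCCn1nc(-c2ccccc2)ccc1=O` — 31.7%
Compound 3 `CC/N=C(\S)NCCCn1nc(-c2ccccc2)ccc1=O` — 39%

In a functional assay on the whole organism with Rattus norvegicus as the target, at a dose of 100 mg/kg (a lower number here means less inhibition, a higher number more inhibition at the dose given (going by the name of the read-out)), compound 1 stands highest of the three, compound 3 nearest and compound 2 furthest from it. The unmeasured compound 4 `C/N=C(/NC#N)N(C)CCCCn1nc(-c2ccccc2)ccc1=O` differs from compound 1 by a group of 8 heavy atoms (4 carbon, 4 nitrogen; no ring) in place of a group of 6 heavy atoms (3 carbon, 2 nitrogen, 1 sulfur; no ring), on a saturated chain carbon, four bonds along the chain from an aromatic nitrogen. Within the data shown here, two measured steps bear on this change. The step of a number 37.2 percentage points lower from compound 1 to compound 2 (beyond the scatter) brings in the same entering group, on a longer chain. The step of a number 29.9 percentage points lower from compound 1 to compound 3 (beyond the scatter) shortens the chain and alters the group. Both point the same way, so a clear fall is expected, the step being estimated as a number 35.9 percentage points lower from compound 1 to compound 4 (beyond the scatter). Compound 4 is therefore expected to give about 33%, within a range from 15% to 55%.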

Compound 4, a percentage reported as inhibition, in the whole organism at one dose (the size of the read-out at that dose, not a potency): 27%
Compound 4: the middle estimate sits 6 percentage points above what was measured; the measured number falls inside the stated range.
By their numbers in this assay, from the lowest: compounds 4, 2 and 3 (each within the scatter of the next, the first and the last beyond it); then compound 1.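

In this assay, the group of 8 heavy atoms in place of the group of 6 heavy atoms, on a saturated chain carbon four bonds along the chain from an aromatic nitrogen, gives a number 41.9 percentage points lower from compound 1 to compound 4 (beyond the scatter). This large fall shows that the drop seen with the same entering group in a number 37.2 percentage points lower from compound 1 to compound 2 (beyond the scatter) is not confined to that longer chain.

Nothing available explains the fall. From the compounds shown here alone, how an amine or a carboxylic acid would fare at this position remains open.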